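Bis-benzylidene series: cytotoxicity, the step to compound 4

The source may hold more compounds than are shown below. What is called first, only, known or untested is meant among the compounds shown, and "the series" means these compounds.

compound 1 `COc1ccccc1/C=c1/[nH]c(=O)/c(=C\c2ccccc2OC)n(C)c1=O` — 1500 nM
compound 2 `C=CCn1c(=O)/c(=C\c2cccc(Cl)c2Cl)[nH]c(=O)/c1=C\c1ccccc1OC` — 500 nM
compound 3 `C=CCn1c(=O)/c(=C\c2ccc(Cl)c(Cl)c2)[nH]c(=O)/c1=C\c1ccccc1OC` — "not active" (no number reported), no number reported

In a functional assay on U-937 cells (Homo sapiens) for cytotoxicity, read by CCK-8 assay, with a stated time of 72 h (a lower number here means a stronger inhibitor, a higher number a weaker inhibitor), compound 1 gives 1500 nM and compound 2 gives 500 nM. Compound 3 gives "not active" (no number reported) in this assay and no number; it is recorded only as not active, so it stands apart from both numbered compounds, with no value that would set a distance to them. Compound 4 `C=CCn1c(=O)/c(=C\c2ccccc2OC)[nH]c(=O)/c1=C\c1ccccc1OC` is the unmeasured member of the set.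

From compound 3 to compound 4 the change is 2-methoxyphenyl in place of 3,4-dichlorophenyl on a double-bonded chain carbon bound to an aromatic carbon. Among the measured compounds shown here, no step between measured compounds covers this change, so its size cannot be read from the data. The direction is expected toward a stronger inhibitor in this assay, because compound 1 gives 1500 nM while carrying the 2-methoxyphenyl group on both double-bonded chain carbons, a measured number where compound 3 has none. Compound 2 carries a different dichlorophenyl pattern and does not bear on this step. The expectation for compound 4 rests on compound 1 alone, and the range is set wide accordingly. Compound 4 is estimated at 1500 nM in this assay, expected between 400 nM and 6000 nM.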

Compound 4, half-maximal inhibitory concentration: 5100 nM
The estimate for compound 4 lay 3.4-fold (0.53 log units) below the measured number; the range from low to high includes it.
By their numbers in this assay, from the lowest: compound 2; then compound 1; then compound 4.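

In this assay, the place on a double-bonded chain carbon bound to an aromatic carbon now has a readable step: 2-methoxyphenyl in place of 2,3-dichlorophenyl gives a 10-fold higher number from compound 2 to compound 4 (1.01 log units; beyond the scatter), while compound 4 carries a number where compound 3, with 3,4-dichlorophenyl at that place, is recorded only as not active. The group at this place therefore moves the read-out in both comparisons, with 2,3-dichlorophenyl giving the lowest number of the set, and the chain on the aromatic nitrogen also matters: vinyl in place of hydrogen on the saturated chain carbon bound to that nitrogen gives a 3.4-fold higher number from compound 1 to compound 4 (0.53 log units; beyond the scatter). No measured property bears on why either step runs as it does.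

Still open, as far as these compounds go, is whether the chain step would keep its direction and size with 2,3-dichlorophenyl in place of 2-methoxyphenyl, and how a longer chain on the aromatic nitrogen would read. Also open, from the compounds shown here alone, is how an amine or a carboxylic acid on the aromatic ring at the changed place would compare with the chlorine and methoxy groups seen so far.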